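Pyrimidine ether in the cytotoxicity set: another limit expected

This account rests on a few compounds, and the source may have more. Where it says the series, first, only, none or still open, it means among the compounds named here.

The series shares one core, shown by compound 1 `CC(C)(C)C#Cc1cc(N(C(=O)[C@H]2CC[C@H](C)CC2)[C@H]2CC[C@H](OC3CCOC3)CC2)c(C(=O)O)s1`. In an ADME assay on MT4 cells (Homo sapiens) for cytotoxicity, with a stated time of 5 days (on this read-out lower numbers stand for higher toxicity in this test and higher numbers for lower toxicity in this test), compound 1 gives > 20000 nM, which is a limit of the assay and not a measured number. Compound 2 `CC(C)(C)C#Cc1cc(N(C(=O)[C@H]2CC[C@H](C)CC2)[C@H]2C[C@@H](Oc3cccnc3)C2)c(C(=O)O)s1` carries a different group on the amide-type nitrogen. In this assay compound 2 gives > 20000 nM, again only a limit. Compound 3 `CC(C)N(c1cc(C#CC(C)(C)C)sc1C(=O)O)C(=O)[C@H]1CC[C@H](C)CC1` is the third member. In this assay compound 3 gives > 20000 nM, also a limit. Because all three values sit at the limit of > 20000 nM in this assay, at which 3 of the 3 values shown sit, none of the steps between them can be read: a step that the two limits leave unreadable from compound 1 to compound 2, a step that the two limits leave unreadable from compound 1 to compound 3 and a step that the two limits leave unreadable from compound 2 to compound 3. Compound 1 therefore stands at the limit together with the other two, with nothing to separate them.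

Compound 4 `CC(C)(C)C#Cc1cc(N(C(=O)[C@H]2CC[C@H](C)CC2)[C@H]2CC[C@H](Oc3ccncn3)CC2)c(C(=O)O)s1` differs from compound 1 in one place: pyrimidin-4-yl in place of oxolan-3-yl on an oxygen on a saturated carbon. Within the data shown here, no measured step bears on this change, since every step in the set is unreadable; three different groups on the amide-type nitrogen all ended at the same limit. The expectation is therefore no step beyond the scatter, a step that the limit leaves unreadable from compound 1 to compound 4, and most probably another limit. Compound 4 is estimated in this assay at 30000 nM, expected to lie between 12000 nM and 80000 nM.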

Compound 4, half-maximal cytotoxic concentration: > 20000 nM
Compound 4 gave a limit, no number (the forecaster's own chance of this, stated with the estimate: 85%); the middle value lies beyond the limit too.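

In this assay compound 4 gives > 20000 nM as a limit of the assay and not a number. No step from compound 1 to compound 4 can be read, and neither can any other step among compound 1, compound 2, compound 3 and compound 4: the limit of > 20000 nM in this assay, at which 4 of the 4 values shown sit.

What the compounds shown leave open is at what concentration, if any, a change on the shared core would show cytotoxicity in these cells.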